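This account rests on a few compounds, and the source may have more. Where it says the series, first, only, none or still open, it means among the compounds named here.

Measured so far in an assay on tissue (HeLa cells) for inhibition of Indoleamine 2,3-dioxygenase 1 (Homo sapiens), with a stated time of 48 h; on this read-out higher numbers stand for weaker inhibition and lower numbers for stronger inhibition:
compound 1 `O=C(/C(=N/O)Nc1ccc(F)c(Br)c1)C1CCN(C(=O)NCc2ccccc2)CC1` gives 28 nM
compound 2 `O=C(/C(=N/O)Nc1ccc(F)c(Br)c1)C1CCN(C(=O)Nc2ccccc2)CC1` gives 54 nM

Both measured compounds share one core and differ only in the group on the amide-type nitrogen. Going a 1.9-fold higher number from compound 1 to compound 2 (0.29 log units; within the scatter), so the two numbers cannot be told apart. Compound 2 has the higher of the two numbers, with compound 1 nearest, but that gap is within the scatter, so compound 2 is neither stronger nor weaker than compound 1 on this evidence.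

Compound 3 `O=C(/C(=N/O)Nc1ccc(F)c(Br)c1)C1CCN(S(=O)(=O)Nc2ccccc2)CC1` is not yet measured. Its change from compound 2 is phenylsulfamoyl in place of phenylcarbamoyl on an amine nitrogen in a ring. Going by the values given here, no measured step concerns this kind of exchange: the one step available, between compound 1 and compound 2, alters a different part of the molecule and was itself within the scatter. The numbers give no basis for expecting a shift in this assay in either direction, only a result near compound 2 with wide uncertainty. Compound 3 is therefore estimated at 70 nM, expected to fall between 25 nM and 200 nM. The expected step is a 1.3-fold higher number from compound 2 to compound 3 (0.11 log units; within the scatter).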

Compound 3, half-maximal inhibitory concentration: 150 nM
For compound 3 the middle estimate is 2.1-fold (0.33 log units) below the measured one; the measured number falls inside the stated range.
By their numbers in this assay, from the lowest: compounds 1 and 2 (each within the scatter of the next); then compound 3.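

In this assay, going by these compounds alone, the link that joins the phenyl group to the amine nitrogen in the ring turns out to matter: phenylsulfamoyl in place of phenylcarbamoyl gives a 2.8-fold higher number from compound 2 to compound 3 (0.44 log units; beyond the scatter), a modest change, but the first single exchange here that stands beyond the scatter. Phenylsulfamoyl in place of benzylcarbamoyl gives a 5.4-fold higher number from compound 1 to compound 3 (0.73 log units; beyond the scatter), so compound 3 is the weakest inhibitor of the three, while the other two could not be told apart. The aromatic ring and the count of hydrogen-bond donors stay the same from compound 2 to compound 3, but no measurement at hand says what lies behind the rise.

From the compounds shown here alone, it remains open whether a benzylsulfamoyl group would show the same rise, which would test the sulfamoyl link on the benzyl side as well as the phenyl side. It is also unknown how this ring nitrogen would respond to a small acetyl group, or to a phenyl group that carries an amine or a carboxylic acid.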